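Trifluoromethoxy in place of trifluoromethyl: notes on compound 4

The source may report more compounds than this note shows. Statements on the series, on what has been measured and on what is new or still open speak of the compounds shown alone.

Of the compounds shown here, three sharing one core have been read in a functional assay on MDA-MB-231 cells (Homo sapiens) for antiproliferative activity, read by MTT assay, with a stated time of 72 h; a lower number here means a stronger inhibitor, a higher number a weaker inhibitor. Compound 1 `O=S1(=O)C=Cc2ccc(Nc3cccc(C(F)(F)F)c3)cc21` gives 1310 nM, and compound 3 `COc1cc(Nc2ccc3c(c2)S(=O)(=O)C=C3)cc(OC)c1OC` gives 1430 nM, two values within the scatter of each other. Compound 2 `O=S1(=O)C=Cc2ccc(Nc3ccc(F)c(F)c3)cc21` gives 3050 nM, a higher number than that of compound 1 and beyond the scatter. Compound 1 therefore stands level with compound 3 and apart from compound 2, though only by a small margin.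

Compound 4 `O=S1(=O)C=Cc2ccc(Nc3cccc(OC(F)(F)F)c3)cc21` has not yet been measured. It differs from compound 1 in one place, with trifluoromethoxy in place of trifluoromethyl on an aromatic carbon, meta to a large group (trifluoromethoxy in place of trifluoromethyl on an aromatic carbon).

Among the compounds with values here, the measured compounds include no pair that differs in one place, so no single change has a direct measure here. The expectation rests instead on the narrow spread between compound 1 at 1310 nM and compound 2 at 3050 nM, although these two differ in more than one place. No step beyond the scatter is expected in this assay, with no firm direction. The estimate is a 1.1-fold higher number from compound 1 to compound 4 (0.03 log units; within the scatter). For compound 4 the expected value is 1400 nM, with an estimated range of 650 nM to 3100 nM.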

Compound 4, half-maximal inhibitory concentration: 2080 nM
Beside the measured number, compound 4's estimate is 1.5-fold (0.17 log units) below it; the range from low to high includes it.
By their numbers in this assay, from the lowest: compounds 1, 3, 4 and 2 (each within the scatter of the next, the first and the last beyond it).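

At this position, on an aromatic carbon meta to a large group, the results now include a direct measure of a single change: in this assay, trifluoromethoxy in place of trifluoromethyl gives a 1.6-fold higher number from compound 1 to compound 4 (0.20 log units; within the scatter) on the shared core. The earlier compounds shown here offered no such pair, and this one shows that the oxygen entering with trifluoromethoxy does not move the number beyond the usual scatter of repeated measurements, so the change is tolerated here, without a reliable direction. No measured evidence bears on the origin of this small step, so the reading goes no further than the number itself.

Within the data shown here, the single pair leaves open whether this position responds at all to a wider change of group, since trifluoromethyl and trifluoromethoxy are the only groups here compared directly on it. An amine, a carboxylic acid or a longer chain such as butoxy at the same place would test that, and the same exchange at another place on the ring would show whether this result holds beyond this position.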